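Ethylsulfonamide series: amidine-type ring in place of pyrrolidine

The source may report more compounds than this note shows. Statements on the series, on what has been measured and on what is new or still open speak of the compounds shown alone.

The series is followed in an assay on isolated protein for binding affinity to Alpha-1A adrenergic receptor (Rattus norvegicus), read by radioligand binding; a lower number here means a stronger inhibitor, a higher number a weaker inhibitor. Compound 1 `CS(=O)(=O)Nc1ccc(Cl)c2c1CCCC2c1c[nH]cn1` gives 447 nM in this assay. Among the measured compounds shown here, compound 2 `CCS(=O)(=O)Nc1cccc(C2CCNC2)c1` gives 501 nM in this assay; of the two numbers so far it is the higher one, but its gap to compound 1 lies within the usual scatter, so no order between the two can be read from these values. Compound 3 `CCS(=O)(=O)Nc1cccc(NC2=NCCN2)c1` keeps the ethylsulfonamide and the six-membered aromatic ring of carbon only and differs from compound 2 in one place: a group of 6 heavy atoms (3 carbon, 3 nitrogen; one five-membered non-aromatic ring with 2 hetero atoms) in place of a group of 5 heavy atoms (4 carbon, 1 nitrogen; one five-membered non-aromatic ring with 1 hetero atom), on an aromatic carbon The change sits on an aromatic carbon of that ring, meta to a group of 6 heavy atoms. For the measured compounds named here, no measured pair carries this change, so the size of the step is open. For compound 3 a step of a 4.2-fold lower number from compound 2 to compound 3 (0.62 log units; beyond the scatter) toward a lower number is expected in this assay, beyond the scatter. Compound 3 is therefore estimated at 120 nM, within a range from 25 nM to 600 nM.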

Compound 3, inhibition constant: 2950 nM
Compound 3: middle estimate off by 25-fold (1.39 log units), on the low side; the whole stated range lies below it.
By their numbers in this assay, from the lowest: compounds 1 and 2 (each within the scatter of the next); then compound 3.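

In this assay, among the compounds shown here, the only single-place change, pyrrolidin-3-yl replaced by the five-membered non-aromatic ring with 2 hetero atoms, gives a 5.9-fold higher number from compound 2 to compound 3 (0.77 log units; beyond the scatter) and so goes against a lower number. This shows that the number responds to the group held on this aromatic carbon, which compound 1 and compound 2 could not show, since they differ in more than one place. The direction rests on this one pair, and nothing measured here accounts for the step.

Going by these compounds, it remains open whether the step comes from the second ring nitrogen, from the nitrogen joining the ring to the aromatic carbon, or from the ring as a whole. A piperidine ring or an aminomethyl group at this place would test whether the higher number is specific to this ring.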